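Replacing Isobutyl with 4-Methoxyphenyl: Expected Cytotoxicity

The source may hold more compounds than are shown below. What is called first, only, known or untested is meant among the compounds shown, and "the series" means these compounds.

Measured in an ADME assay on HepG2 cells (Homo sapiens) for cytotoxicity, read by luminescence, CellTiter-Glo and ATP content, with a stated time of 72 h; on this read-out higher numbers stand for an effect only at larger amounts of compound and lower numbers for an effect already at smaller amounts:
compound 1 `COc1cccc(CNCCCNc2ccnc3cc(Oc4ccc(Cl)cc4)ccc23)c1O`: 5700 nM
compound 2 `COc1cccc(CNCCCNc2ccnc3cc(Oc4cccc(N(C)C)c4)ccc23)c1O`: 7300 nM
compound 3 `COc1cccc(CNCCCNc2ccnc3cc(CC(C)C)ccc23)c1O`: 2920 nM

Compound 3 has the lowest number of the three. Its nearest neighbour is compound 1, with a 2.0-fold lower number from compound 1 to compound 3 (0.29 log units; within the scatter); the step of a 2.5-fold lower number from compound 2 to compound 3 (0.40 log units; beyond the scatter) is the largest gap. Compound 4 `COc1ccc(-c2ccc3c(NCCCNCc4cccc(OC)c4O)ccnc3c2)cc1` differs from compound 3 in one place: 4-methoxyphenyl in place of isobutyl on an aromatic carbon. Going by the values given here, the two steps that bear on this change both swapped an aromatic group for isobutyl and lowered the number, so putting an aromatic group back is expected to raise it modestly; no measured step attaches a ring directly to this carbon, so the expectation is loose. The expected step is a 1.7-fold higher number from compound 3 to compound 4 (0.23 log units; within the scatter). Compound 4 is therefore estimated at 5000 nM, within a range from 2000 nM to 12500 nM.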

Compound 4, half-maximal effective concentration: 1600 nM
Estimate against measurement, compound 4: 3.1-fold (0.49 log units) above, outside the stated range (below it).
By their numbers in this assay, from the lowest: compounds 4, 3, 1 and 2 (each within the scatter of the next, the first and the last beyond it).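

In this assay, bonding 4-methoxyphenyl directly to this aromatic carbon gives a 1.8-fold lower number from compound 3 to compound 4 (0.26 log units; within the scatter), so here an aromatic ring in place of isobutyl does not raise the number. Against the rings attached through oxygen, it gives a 3.6-fold lower number from compound 1 to compound 4 (0.55 log units; beyond the scatter) and a 4.6-fold lower number from compound 2 to compound 4 (0.66 log units; beyond the scatter), although each of these steps changes both the oxygen link and the ring's substituent. No evidence here explains these differences.

As far as these compounds go, the effect of the oxygen link alone remains open, and 4-methoxyphenoxy on this carbon would separate it from the ring's substituent. From the compounds shown here alone, how an amine or a carboxylic acid would behave here is also open.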